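The source may report more compounds than this note shows. Statements on the series, on what has been measured and on what is new or still open speak of the compounds shown alone.

Within the data shown here, in a functional assay on Raji cells (Homo sapiens) for cytotoxicity, read by CCK-8 assay, with a stated time of 24 h (a lower number here means a stronger inhibitor, a higher number a weaker inhibitor), compound 2 `C=CC(=O)N1C(=O)CC(c2ccc(Cl)cc2)Sc2ccccc21` gives 18400 nM, the lower of the two numbers measured so far. Among the measured compounds shown here, the only other measured compound, compound 1 `C=CC(=O)N1C(=O)CC(C)Sc2ccccc21`, gives 837000 nM. Compound 3 `C=CC(=O)N1C(=O)CCSc2ccccc21` is still unmeasured and differs from compound 2 in one place: hydrogen in place of 4-chlorophenyl on a saturated ring carbon. Put simply, hydrogen sits in place of 4-chlorophenyl on a saturated ring carbon. For the measured compounds named here, only one measured step bears on this change, the one in which 4-chlorophenyl replaced methyl on a saturated ring carbon. Compound 3 also lacks the 4-chlorophenyl, so, reading a 45-fold lower number from compound 1 to compound 2 (1.66 log units; beyond the scatter) backwards, a large rise in the number is expected, beyond the scatter. The estimated step is a 27-fold higher number from compound 2 to compound 3 (1.43 log units; beyond the scatter). For compound 3 the expected value is 500000 nM, with an estimated range of 120000 nM to 2000000 nM.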

Compound 3, half-maximal inhibitory concentration: 581000 nM
Beside the measured number, compound 3's estimate is 1.2-fold (0.07 log units) below it, within the range that was stated.
By their numbers in this assay, from the lowest: compound 2; then compounds 3 and 1 (each within the scatter of the next).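

Replacing the 4-chlorophenyl with hydrogen on this saturated ring carbon gives, in this assay, a 32-fold higher number from compound 2 to compound 3 (1.50 log units; beyond the scatter) and this large step is matched by a 1.4-fold lower number from compound 1 to compound 3 (0.16 log units; within the scatter) when hydrogen takes the place of methyl. Hydrogen and methyl therefore cannot be told apart at this position, and among these three compounds only the one carrying 4-chlorophenyl stands out, so the earlier drop in the number did not merely reflect a change away from methyl. Nothing available explains why this group makes such a difference. Still open, on these data alone, is whether the benzene ring alone is enough or the chlorine is also needed, as a plain phenyl or a longer chain such as butyl at this carbon would show. The vinylcarbonyl group is the same in all three compounds, so its share in the cytotoxicity cannot be read from them.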